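The source may report more compounds than this note shows. Statements on the series, on what has been measured and on what is new or still open speak of the compounds shown alone.

Three compounds of the series share one core and differ only in the chain beyond the amide. For compound 1 `CC(C)(C)OC(=O)NCCCCNC(=O)CN1CN(c2ccccc2)C2(CCN(C(=O)c3ccc(C(C)(C)C)cc3)CC2)C1=O` the entry in an assay on HEK293 cells for displacement of a labelled ligand from NPC1-like intracellular cholesterol transporter 1 (Homo sapiens) (a higher number here means a weaker inhibitor, a lower number a stronger inhibitor), reads "not determined" (no result reported), so no number is on hand for it. Compound 2 `CC(C)(C)c1ccc(C(=O)N2CCC3(CC2)C(=O)N(CC(=O)NCCCCCNS(C)(=O)=O)CN3c2ccccc2)cc1` gives 5500 nM in this assay, and compound 3 `CC(C)(C)OC(=O)NCCCNC(=O)CN1CN(c2ccccc2)C2(CCN(C(=O)c3ccc(C(C)(C)C)cc3)CC2)C1=O` gives 4500 nM in this assay. These two recorded numbers lie within the scatter of each other, so compound 3 is not set apart from compound 2 on what is measured so far. Among the measured compounds shown here, the single measured step, a 1.2-fold lower number from compound 2 to compound 3 (0.09 log units; within the scatter), is within the scatter.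

Compound 4 `CC(C)(C)c1ccc(C(=O)N2CCC3(CC2)C(=O)N(CC(=O)NCCCCNS(C)(=O)=O)CN3c2ccccc2)cc1` is the next entry. For the measured compounds named here, the change (methanesulfonamido)methyl in place of (tert-butoxycarbonyl)amino on a saturated chain carbon, three bonds along the chain from an amide-type nitrogen comes close to reversing the one step already seen, cut one chain carbon shorter, with (tert-butoxycarbonyl)amino leaving and a methanesulfonamido group entering. With a 1.2-fold lower number from compound 2 to compound 3 (0.09 log units; within the scatter) lying within the scatter, no movement beyond scatter is expected in this assay for compound 4 either. The step of a 1.1-fold higher number from compound 3 to compound 4 (0.05 log units; within the scatter) is expected to be flat. Compound 4 is therefore estimated at 5000 nM, with a range from 2000 nM to 12000 nM.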

Compound 4, half-maximal inhibitory concentration: 4500 nM
Compound 4: the middle estimate sits 1.1-fold (0.05 log units) above what was measured, within the range that was stated.
By their numbers in this assay, from the lowest: compounds 3, 4 and 2 (each within the scatter of the next).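

In this assay the exchange of (tert-butoxycarbonyl)amino for (methanesulfonamido)methyl on a saturated chain carbon, three bonds along the chain from an amide-type nitrogen, reads as no change at the digits printed from compound 3 to compound 4 (within the scatter) and so shows no separation between these two end groups. The second comparison holds the methanesulfonamido end group and changes only the chain, with methanesulfonamido in place of (methanesulfonamido)methyl on a saturated chain carbon, four bonds along the chain from an amide-type nitrogen; it reads as a 1.2-fold lower number from compound 2 to compound 4 (0.09 log units; within the scatter) and adds no separation on chain length. Compounds 2, 3 and 4 therefore stay together, and neither change moves the number beyond the scatter.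

From the compounds shown here alone, whether a free amine, a carboxylic acid or a much longer chain at this position would do so remains open. Nothing on hand accounts for these flat readings.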